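Nitro for chloro on a thiourea-bearing phenyl ring

The source may report more compounds than this note shows. Statements on the series, on what has been measured and on what is new or still open speak of the compounds shown alone.

Three related compounds have been measured in an assay for binding affinity to Apoptosis regulator Bcl-2 (Homo sapiens), read by fluorescence polarization, with stated times of 30 min and 20 min, tested at 100 uM; a higher number here means more inhibition at the concentration tested (going by the name of the read-out), a lower number less inhibition. Compound 2 `COc1ccc(Oc2ccc([N+](=O)[O-])cc2-c2ccsc2S(=O)(=O)N2CCN(C(=S)Nc3ccc(Cl)cc3)CC2)cc1OC` gives 18%, the highest of the three numbers. Compound 1 `COc1ccc(Oc2ccccc2-c2ccsc2S(=O)(=O)N2CCN(C(=S)Nc3ccc([N+](=O)[O-])cc3)CC2)cc1OC` gives 16% in this assay, which lies within the usual scatter of the value for compound 2. Compound 3 `O=C(Nc1cc(C(F)(F)F)cc(C(F)(F)F)c1)N1CCN(S(=O)(=O)c2sccc2-c2ccccc2Oc2ccc(O)c(O)c2)CC1` gives 7% in this assay, which lies beyond that scatter. Compound 4 `COc1ccc(Oc2ccc([N+](=O)[O-])cc2-c2ccsc2S(=O)(=O)N2CCN(C(=S)Nc3ccc([N+](=O)[O-])cc3)CC2)cc1OC` has not yet been measured. It differs from compound 2 in one place: nitro in place of chloro on an aromatic carbon. Among the compounds with values here, no two measured compounds differ in one place, so no measured step guides the expectation. Compound 1, which already carries a nitro on that ring, gives 16% in this assay, so for compound 4 the expected step of no change at the digits printed from compound 2 to compound 4 (within the scatter) is small, with no direction beyond the scatter. Compound 4 is estimated at 18%, between 8% and 28%.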

Compound 4, a percentage reported as inhibition, at one concentration (the size of the read-out at that concentration, not a potency): 16%
Beside the measured number, compound 4's estimate is 2 percentage points above it; the measured number falls inside the stated range.
By their numbers in this assay, from the lowest: compounds 3, 1, 4 and 2 (each within the scatter of the next, the first and the last beyond it).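

In this assay, within the data shown here, replacing chloro with nitro on the thiourea-bearing phenyl ring gives a number 2 percentage points lower from compound 2 to compound 4 (within the scatter), the first measured step at this position, so chloro and nitro cannot be told apart here. Nitro in place of hydrogen on the other aromatic ring gives no change at the digits printed from compound 1 to compound 4 (within the scatter), so this second change also shows no difference beyond the scatter. Nothing available explains either result. These readings come from a single concentration and do not give potency. Going by these compounds, whether an amine or a carboxylic acid at this position would give a different reading remains open.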